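Substituent swaps on the phenoxy ring of one core

This account rests on a few compounds, and the source may have more. Where it says the series, first, only, none or still open, it means among the compounds named here.

Three analogues on a shared core have been measured in a functional assay on SGC-7901 cells (Homo sapiens) for antiproliferative activity, read by MTT assay, with a stated time of 72 h; on this read-out lower numbers stand for stronger inhibition and higher numbers for weaker inhibition. Compound 1 `Cc1nn(C)c(Oc2ccc(F)cc2)c1/C=N\OCc1c(Cl)c(-c2ccc(F)cc2)nn1C` gives 7080 nM; compound 2 `Cc1nn(C)c(Oc2ccc(Cl)cc2)c1/C=N\OCc1c(Cl)c(-c2ccc(F)cc2)nn1C` gives 8110 nM; compound 3 `Cc1ccc(Oc2c(/C=N\OCc3c(Cl)c(-c4ccc(F)cc4)nn3C)c(C)nn2C)cc1` gives 4620 nM, the lowest number shown, though its gaps to compound 1 and compound 2 sit within the scatter. Compound 4 `COc1ccc(Oc2c(/C=N\OCc3c(Cl)c(-c4ccc(F)cc4)nn3C)c(C)nn2C)cc1` is still to be measured and differs from compound 3 by methoxy in place of methyl on an aromatic carbon. For the measured compounds named here, the steps that bear on this position, a 1.5-fold lower number from compound 1 to compound 3 (0.19 log units; within the scatter) and a 1.8-fold lower number from compound 2 to compound 3 (0.24 log units; within the scatter), were both within the scatter, as was a 1.1-fold higher number from compound 1 to compound 2 (0.06 log units; within the scatter). Nothing here points to a step beyond the scatter in either direction. For compound 4 the expected value in this assay is 4800 nM, with a range of 2200 nM to 10500 nM, which amounts to an expected step of a 1.0-fold higher number from compound 3 to compound 4 (0.02 log units; within the scatter).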

Compound 4, half-maximal inhibitory concentration: 2840 nM
Beside the measured number, compound 4's estimate is 1.7-fold (0.23 log units) above it; the measured number falls inside the stated range.
By their numbers in this assay, from the lowest: compounds 4, 3, 1 and 2 (each within the scatter of the next, the first and the last beyond it).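

In this assay, for the compounds shown here, methoxy on this aromatic carbon gives the first steps beyond the scatter at this position, though modest ones: a 2.9-fold lower number from compound 2 to compound 4 (0.46 log units; beyond the scatter) and a 2.5-fold lower number from compound 1 to compound 4 (0.40 log units; beyond the scatter) for the swaps from chloro and fluoro. Against methyl there is no such separation (a 1.6-fold lower number from compound 3 to compound 4 (0.21 log units; within the scatter)), so compound 3 and compound 4 cannot be ranked. No measured finding accounts for these steps.

Still open, going by these compounds, is whether an amine, a carboxylic acid or a longer chain such as ethoxy on this carbon would separate from methoxy and methyl.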